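A few compounds are considered here, and "the series" means these few. Any claim that something is new, unique, unknown or untested is made for them only; others in the source may bear on it.

In a functional assay on MCF7 cells (Homo sapiens) for cytotoxicity, read by MTT assay, with a stated time of 24 h (a lower number here means a stronger inhibitor, a higher number a weaker inhibitor), compound 3 `CN1CCN(CCCSc2nc3ccccc3[nH]2)CC1` gives 77900 nM, the highest of the three numbers measured. Compound 1 `CCOc1ccccc1N1CCN(C(=S)SCc2nc3cc(Cl)c(Cl)cc3[nH]2)CC1` gives 16200 nM and compound 2 `Cc1cc2nc(CSC(=S)N3CCN(c4ccccc4Cl)CC3)[nH]c2cc1C` gives 8390 nM; compound 3 lies beyond the scatter of both, and each differs from it in more than one place, so no single step can be read from them. Compound 4 `Clc1cccc(N2CCN(CCCSc3nc4ccccc4[nH]3)CC2)c1` differs from compound 3 in one place: 3-chlorophenyl in place of methyl on an amine nitrogen in a ring. Because compound 1 gives 16200 nM and compound 2 gives 8390 nM while both carry an aryl group on the corresponding amine nitrogen in a ring, a moderate downward step is expected, as a 3.1-fold lower number from compound 3 to compound 4 (0.49 log units; beyond the scatter). Compound 4 is therefore estimated at 25000 nM, within a range of 8000 nM to 70000 nM.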

Compound 4, half-maximal inhibitory concentration: 54600 nM
For compound 4 the middle estimate is 2.2-fold (0.34 log units) below the measured one; low and high end bracket the measured number.
By their numbers in this assay, from the lowest: compounds 2 and 1 (each within the scatter of the next); then compounds 4 and 3 (each within the scatter of the next).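

In this assay the one-place step at this amine nitrogen is a 1.4-fold lower number from compound 3 to compound 4 (0.15 log units; within the scatter). Thus 3-chlorophenyl, with its seven heavy atoms and aromatic ring, cannot be told apart from methyl, its single carbon, a reading that the earlier compounds, differing in more than one place, could not give. Nothing measured here accounts for this result. On these data alone, whether a benzyl or an acetyl group on this nitrogen would give a step beyond the scatter remains open, as does the effect of a carboxylic acid on the added aromatic ring.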